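A few compounds are considered here, and "the series" means these few. Any claim that something is new, unique, unknown or untested is made for them only; others in the source may bear on it.

Compound 1 `NC(=O)C[C@H](NC(=O)c1ccc(C#Cc2ccccc2)cc1)C(=O)NO` gives 1 in a physicochemical assay for lipophilicity; on this read-out lower numbers stand for lower lipophilicity and higher numbers for higher lipophilicity.
Compound 2 `COCCNC(=O)C[C@H](NC(=O)c1ccc(C#Cc2ccccc2)cc1)C(=O)NO` gives 2 in this assay.
Compound 3 `O=C(NC1(C(=O)NO)CCNCC1)c1ccc(C#Cc2ccccc2)cc1` gives 3 in this assay.

Among these three numbers compound 2 stands second highest: compound 1 is its nearest neighbour and lies beyond the scatter below it, compound 3 its furthest and lies beyond the scatter above it. For the measured compounds named here, the one measured step between compounds that differ in a single place is a number 1.00 log units higher from compound 1 to compound 2 (beyond the scatter), a modest rise on adding the 2-methoxyethyl group. Compound 4 `O=C(C[C@H](NC(=O)c1ccc(C#Cc2ccccc2)cc1)C(=O)NO)NCCCO` differs from compound 2 by hydroxymethyl in place of methoxy on a saturated chain carbon, two bonds along the chain from an amide-type nitrogen. Going by the values given here, no measured pair swaps a methoxy for a hydroxymethyl, so the direction is taken from the count of the change, which adds one hydrogen-bond donor, and in this assay such a change is expected to lower the number. Because a number 1.00 log units higher from compound 1 to compound 2 (beyond the scatter) came from adding the whole 2-methoxyethyl group, the swap within that group is expected to undo only part of the rise. Compound 4 is therefore expected to give 1.4 in this assay, with a range from 0.9 to 1.9. That estimate means an expected a number 0.60 log units lower from compound 2 to compound 4 (beyond the scatter).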

Compound 4, distribution coefficient: 2
For compound 4 the middle estimate is 0.60 log units below the measured one; measured number above the stated range.
By their numbers in this assay, from the lowest: compound 1; then compounds 2 and 4 (each within the scatter of the next); then compound 3.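

In this assay, hydroxymethyl in place of methoxy on a saturated chain carbon, two bonds along the chain from an amide-type nitrogen, gives no change at the digits printed from compound 2 to compound 4 (within the scatter) and so leaves the number in place, even though the change adds a hydrogen-bond donor. Read against compound 1, 3-hydroxypropyl in place of hydrogen on that amide-type nitrogen gives a number 1.00 log units higher from compound 1 to compound 4 (beyond the scatter) and thus matches at the digits printed the step seen with 2-methoxyethyl. No evidence at hand accounts for this result.

The compounds shown leave open whether an amine or a carboxylic acid at the end of this chain would keep the number at this level. They also leave open whether a longer chain ending in hydroxyl would do so.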